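This account rests on a few compounds, and the source may have more. Where it says the series, first, only, none or still open, it means among the compounds named here.

Measured compounds:
compound 1 `CN(C)/C=C/C(=O)c1cc2ccccc2oc1=O` — in a functional assay on T47D cells (Homo sapiens) for cytotoxicity, read by sulforhodamine B assay, with a stated time of 48 h (a higher number here means a weaker inhibitor, a lower number a stronger inhibitor), compound 1 gives 147000 nM
compound 2 `CC(=O)NS(=O)(=O)c1ccc(N/C=C\C(=O)c2cc3ccccc3oc2=O)cc1` — in this assay compound 2 gives no result reported
compound 3 `O=C(/C=C\Nc1ccc(S(=O)(=O)Nc2ncccn2)cc1)c1cc2ccccc2oc1=O` — in this assay compound 3 gives 75200 nM

Compound 3 carries the lower of the two numbers, yet the gap to compound 1 lies within the scatter, so the two values show no real difference. Compound 4 `Nc1ccc(S(=O)(=O)c2ccc(N/C=C\C(=O)c3cc4ccccc4oc3=O)cc2)cc1` is the next candidate. Its change from compound 3 is 4-aminophenyl in place of (pyrimidin-2-yl)amino on a sulfonyl sulfur. Within the data shown here, no step between measured compounds covers this change, and the two numbers present sit within the scatter of each other, so no step beyond the scatter is expected in either direction. Compound 4 is estimated at 70000 nM, range 25000 nM to 200000 nM. The step from compound 3 to compound 4 is expected to be a 1.1-fold lower number from compound 3 to compound 4 (0.03 log units; within the scatter).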

Compound 4, half-maximal inhibitory concentration: 91900 nM
Compound 4: middle estimate off by 1.3-fold (0.12 log units), on the low side; the measured number falls inside the stated range.
By their numbers in this assay, from the lowest: compounds 3, 4 and 1 (each within the scatter of the next).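

On a sulfonyl sulfur, 4-aminophenyl takes the place of (pyrimidin-2-yl)amino in this assay with a 1.2-fold higher number from compound 3 to compound 4 (0.09 log units; within the scatter), so this exchange of one aromatic ring and its link for another leaves the number unchanged within the scatter. The amino link to the sulfonyl sulfur is therefore not needed to keep the number where compound 3 has it. Nothing measured on hand gives a cause for this.

Going by these compounds, whether a small group on the sulfonyl sulfur, such as a plain amine or methyl, would move the number remains open. So does the effect of a carboxylic acid in place of the whole sulfonyl group.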